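Replacing the amide group of compound 3

The source may hold more compounds than are shown below. What is called first, only, known or untested is meant among the compounds shown, and "the series" means these compounds.

In a functional assay on MCF7 cells (Homo sapiens) for antiproliferative activity, read by MTT assay, with a stated time of 48 h (on this read-out lower numbers stand for stronger inhibition and higher numbers for weaker inhibition), compound 1 `C#CC(C)OC(=O)c1ccc(C(CC)(CC)c2ccc(OCCC(O)(CC)CC)c(C)c2)n1CC` reads > 50000 nM, which is a limit. Compound 2 `CCn1c(C(=O)Nc2ccc(OC(F)(F)F)cc2)ccc1C(CC)(CC)c1ccc(OCCC(O)(CC)CC)c(C)c1` reads > 50000 nM, also a limit. Going by the values given here, compound 3 `CCOC(=O)C(CC(=O)OC)NC(=O)c1ccc(C(CC)(CC)c2ccc(OCCC(O)(CC)CC)c(C)c2)n1CC` gives 390 nM, the only actual number so far. Compound 4 `CCn1c(C(=O)NC(C)C(=O)O)ccc1C(CC)(CC)c1ccc(OCCC(O)(CC)CC)c(C)c1` differs from it in one place: a group of 5 heavy atoms (3 carbon, 2 oxygen; no ring) in place of a group of 11 heavy atoms (7 carbon, 4 oxygen; no ring), on an amide-type nitrogen, so that 1-carboxyethyl stands on the amide-type nitrogen. Among the compounds with values here, two measured steps bear on this change, and both are large: an at least 120-fold lower number from compound 1 to compound 3 (2.10 log units; beyond the scatter), and an at least 120-fold lower number from compound 2 to compound 3 (2.10 log units; beyond the scatter). The second of these swaps the group on that same nitrogen, so a sizeable move towards weaker inhibition is expected on losing the group of compound 3. The expected change is a 13-fold higher number from compound 3 to compound 4 (1.11 log units; beyond the scatter). The estimate for compound 4 is 5000 nM, within a range of 500 nM to 50000 nM.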

Compound 4, half-maximal inhibitory concentration: 19700 nM
For compound 4 the middle estimate is 3.9-fold (0.60 log units) below the measured one, within the range that was stated.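

In this assay, the group on the amide-type nitrogen matters even among groups without a ring: 1-carboxyethyl in place of the chain of compound 3 gives a 51-fold higher number from compound 3 to compound 4 (1.70 log units; beyond the scatter). Compound 4 nevertheless keeps a readable value, with an at least 2.5-fold lower number from compound 2 to compound 4 (0.40 log units; beyond the scatter) and an at least 2.5-fold lower number from compound 1 to compound 4 (0.40 log units; beyond the scatter). These last two steps are bounded on one side only: the limit of > 50000 nM in this assay, at which 2 of the 4 values shown sit.

The compounds shown do not separate the shorter chain from the free carboxylic acid. The methyl ester of 1-carboxyethyl on that nitrogen would bear on this, as would a longer chain ending in a carboxylic acid.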